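This account rests on a few compounds, and the source may have more. Where it says the series, first, only, none or still open, it means among the compounds named here.

In a functional assay on HeLa cells (Homo sapiens) for antiproliferative activity, read by MTT assay, with a stated time of 72 h (on this read-out higher numbers stand for weaker inhibition and lower numbers for stronger inhibition), three compounds sharing one core have been measured. Compound 1 `C/C=C/C(=O)Nc1cccc(Oc2nc(Nc3ccn(C)n3)nc3c2CSCC3)c1` gives > 50000 nM, which is a limit of the assay and not a number. Compound 2 `C/C=C/C(=O)Nc1cccc(Oc2nc(Nc3cccc(OC)c3)nc3c2CSCC3)c1` gives 13800 nM. Compound 3 `C=CC(=O)Nc1cccc(Oc2nc(Nc3ccc(OC)cc3)nc3c2CSCC3)c1` gives 20900 nM, and this lies within the usual scatter of the value for compound 2, so the two cannot be ranked.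

Compound 4 `C/C=C/C(=O)Nc1cccc(Oc2nc(Nc3ccc(OC)cc3)nc3c2CSCC3)c1` differs from compound 3 in one place: prop-1-en-1-yl in place of vinyl on a carbonyl carbon. Put simply, prop-1-en-1-yl stands in place of vinyl on a carbonyl carbon. Among the measured compounds shown here, the only measured step, an at least 3.6-fold lower number from compound 1 to compound 2 (0.55 log units; beyond the scatter), comes from a different change: 3-methoxyphenyl in place of 1-methyl-1H-pyrazol-3-yl on a nitrogen on an aromatic ring. For the measured compounds named here, it therefore gives no direct guide to this swap, and no measured pair isolates it. The closest hint is compound 2, which already carries prop-1-en-1-yl on that carbonyl carbon and gives 13800 nM, close to the value for compound 3.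

No shift beyond the scatter is therefore expected, and the estimated change is a 1.1-fold lower number from compound 3 to compound 4 (0.04 log units; within the scatter). For compound 4, the estimated value in this assay is 19000 nM, with an expected range from 9000 nM to 42000 nM.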

Compound 4, half-maximal inhibitory concentration: > 50000 nM
Compound 4: no number, only a limit (the forecaster's own chance of this, stated with the estimate: 10%); middle value at least 2.6-fold (0.42 log units) from the limit.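

In this assay, the swap at this position finally has a measured pair: prop-1-en-1-yl in place of vinyl on a carbonyl carbon, with an amide-type nitrogen as its other neighbour, gives an at least 2.3-fold higher number from compound 3 to compound 4 (0.37 log units; beyond the scatter), which means weaker inhibition. The result also shows that, with prop-1-en-1-yl kept on that carbonyl carbon, the group on the nitrogen still matters, as 4-methoxyphenyl in place of 3-methoxyphenyl gives an at least 3.6-fold higher number from compound 2 to compound 4 (0.55 log units; beyond the scatter). Compound 4 sits at a limit of the assay and not at a number, as does compound 1, so the step between those two cannot be read: the limit of > 50000 nM in this assay, at which 2 of the 4 values shown sit.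

Among the compounds shown here, only one pair isolates the vinyl to prop-1-en-1-yl swap, so it remains open whether the same step would appear with 3-methoxyphenyl or 1-methyl-1H-pyrazol-3-yl on the nitrogen in place of 4-methoxyphenyl. Also open, on these data alone, is what a longer chain, such as but-1-en-1-yl, or a chain ending in a dimethylamine, would do on the same carbonyl carbon, and whether any such group would bring the number down again.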